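Replacing the 4-fluorophenyl group of compound 3

The source may report more compounds than this note shows. Statements on the series, on what has been measured and on what is new or still open speak of the compounds shown alone.

Compound 1 `COc1cccc(/C=C/C(=O)/C=C(O)/C=C/c2cccc(OC)c2OC)c1OC` gives 12800 nM
Compound 2 `COc1ccc(OC)c(/C=C/C(=O)/C=C(O)/C=C/c2cc(OC)ccc2OC)c1` gives 14700 nM
Compound 3 `COc1cccc(/C=C/C(=O)C(=Cc2ccc(F)cc2)C(=O)/C=C/c2cccc(OC)c2OC)c1OC` gives 610 nM

These three values come from a functional assay on CNE-2 cells (Homo sapiens) for antiproliferative activity, read by sulforhodamine B assay, with a stated time of 48 h (on this read-out lower numbers stand for stronger inhibition and higher numbers for weaker inhibition), and make up everything measured so far. Compound 3 stands lowest at 610 nM and is therefore the strongest inhibitor of the three, well clear of the other two, whose values lie within the usual scatter of each other.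

Compound 4 `COc1cc(C=C(C(=O)/C=C/c2cccc(OC)c2OC)C(=O)/C=C/c2cccc(OC)c2OC)ccc1O` has not yet been measured. It carries 4-hydroxy-3-methoxyphenyl in place of 4-fluorophenyl on a double-bonded chain carbon bound to a double-bonded chain carbon and is otherwise the same as compound 3 apart from the rest of the change shown there. For the measured compounds named here, no measured pair shows what this exchange does, so any expectation here is loose. Going by the values given here, compound 3 at 610 nM holds the lowest number so far, which leaves more room for a rise than a further fall. A modest weakening is expected, with the estimated step being a 2.5-fold higher number from compound 3 to compound 4 (0.39 log units; beyond the scatter) in this assay and little confidence in its exact size. For compound 4 the estimated value is 1500 nM, with an expected range from 400 nM to 5500 nM.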

Compound 4, half-maximal inhibitory concentration: 280 nM
Compound 4: middle estimate off by 5.4-fold (0.73 log units), on the high side; the measured number lies below the stated range.
By their numbers in this assay, from the lowest: compound 4; then compound 3; then compounds 1 and 2 (each within the scatter of the next).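

In this assay, putting 4-hydroxy-3-methoxyphenyl in place of 4-fluorophenyl on a double-bonded chain carbon bound to a double-bonded chain carbon gives a 2.2-fold lower number from compound 3 to compound 4 (0.34 log units; beyond the scatter), a modest step that is nonetheless beyond the scatter. For the compounds shown here, this is the first change at a single place that can be read, and it shows that this position tolerates the swap from a group of 7 heavy atoms with no hydrogen-bond donors or acceptors to one of 9 heavy atoms that carries both, with inhibition growing stronger rather than weaker. Nothing available explains why the number falls with this exchange.

The compounds shown leave open whether the hydroxy group, the methoxy group or the two together carry this step; they enter together in this one change. Also open, on these data alone, is how the number would move with an amine or a carboxylic acid on the phenyl ring at this place, and whether the step would hold on the other dimethoxyphenyl pattern seen in compound 2.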